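Swapping Methyl for Fluoro on an Aryl Ring

The source may hold more compounds than are shown below. What is called first, only, known or untested is meant among the compounds shown, and "the series" means these compounds.

For the measured compounds named here, compound 1 `COc1ncc(-c2ccc3c(c2)N(c2ccc(C)cc2)C(=O)CO3)cc1NS(=O)(=O)c1ccc(F)cc1` is the one compound here with a measured number. In a functional assay on A549 cells (Homo sapiens) for antiproliferative activity, read by MTT assay, with a stated time of 72 h (a higher number here means a weaker inhibitor, a lower number a stronger inhibitor), compound 1 gives 5870 nM. Compound 2 `O=C1COc2ccc(-c3cnc4ccccc4c3)cc2N1c1ccccc1` shares the core but carries a different aromatic group. In this assay compound 2 reaches only > 40000 nM, which is a limit of the assay and not a number. Compound 3 `O=C1COc2ccc(-c3cnc4ccccc4c3)cc2N1`, with hydrogen in place of phenyl on an amide-type nitrogen in a ring, likewise stops at > 40000 nM in this assay, again a limit rather than a number. The step that the two limits leave unreadable from compound 2 to compound 3 therefore cannot be read, because the limit of > 40000 nM in this assay, at which 2 of the 3 values shown sit, fixes nothing about its size. Compound 4 `COc1ncc(-c2ccc3c(c2)N(c2ccc(F)cc2)C(=O)CO3)cc1NS(=O)(=O)c1ccc(F)cc1` differs from compound 1 by fluoro in place of methyl on an aromatic carbon. Going by the values given here, no measured step touches this place on the structure, so no step beyond the scatter is expected in this assay, in either direction, and compound 4 is expected to sit close to compound 1. The step expected is a 1.0-fold higher number from compound 1 to compound 4 (0.01 log units; within the scatter). Compound 4 is estimated at 6000 nM, between 2500 nM and 15000 nM.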

Compound 4, half-maximal inhibitory concentration: 6500 nM
Beside the measured number, compound 4's estimate is 1.1-fold (0.03 log units) below it; the range from low to high includes it.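

In this assay, for the compounds shown here, the change from 4-methylphenyl to 4-fluorophenyl gives a 1.1-fold higher number from compound 1 to compound 4 (0.04 log units; within the scatter), so this place on the ring now has a readable step, which the earlier compounds did not provide. Fluoro and methyl therefore read alike here, but this describes only these two groups in this one pair and sets no rule for the position as a whole. Nothing measured in this set accounts for this likeness.

From the compounds shown here alone, whether a methoxy group, an amine or a carboxylic acid at this place would shift the number stays open. Also open is how hydrogen in place of the aryl group on the amide-type nitrogen would read in the series of compound 1, as the one such change shown runs between two limits.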